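The source may report more compounds than this note shows. Statements on the series, on what has been measured and on what is new or still open speak of the compounds shown alone.

Of the compounds shown here, two have been measured in a functional assay on HEK293 cells for agonist activity at Glucose-dependent insulinotropic receptor (Homo sapiens), read by cAMP accumulation, with a stated time of 30 min; on this read-out lower numbers stand for an effect already at smaller amounts and higher numbers for an effect only at larger amounts of compound. Compound 1, `CN(C)C(=O)c1ccc(OCCCCCC2CCC3(CC2)OCCCO3)cc1`, gives 29 nM in this assay. Compound 2, `CN(C)C(=O)c1ccc(OCCCCC[C@H]2CC[C@]3(CCCCO3)CC2)cc1`, gives 36 nM in this assay, the higher of the two numbers, though the gap to compound 1 lies within the scatter of repeated measurements, so the two cannot be ranked.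

Compound 3, `CN(C)C(=O)c1ccc(OCCCCC[C@H]2CC[C@@]3(CCCCO3)CC2)cc1`, is not yet measured. It differs from compound 2 in the following way: the two compounds have the same atoms and bonds and differ only in configuration as drawn: 2 of 2 stereo elements differ (all stereocentres are inverted: mirror images); a stereocentre at a saturated ring carbon is drawn r in compound 2 and s in compound 3; a stereocentre at a saturated ring carbon is drawn r in compound 2 and s in compound 3. Compound 3 is thus the mirror image of compound 2 at both saturated ring carbons.

Going by the values given here, no measured pair here shows what such an inversion does, so the size of the step is open. Mirror-image pairs often differ well beyond the scatter, and the direction can go either way. For compound 3 a weaker effect than compound 2 is expected in this assay, with the step of a 3.1-fold higher number from compound 2 to compound 3 (0.49 log units; beyond the scatter) as the estimate, giving an expected value of 110 nM, within a range from 20 nM to 900 nM.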

Compound 3, half-maximal effective concentration: 21 nM
Compound 3: middle estimate off by 5.2-fold (0.72 log units), on the high side; measured number inside the range.
By their numbers in this assay, from the lowest: compounds 3, 1 and 2 (each within the scatter of the next).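

Inverting both saturated ring carbons gives a 1.7-fold lower number from compound 2 to compound 3 (0.23 log units; within the scatter) in this assay, so this mirror-image pair cannot be ranked. Going by these compounds alone, this is the first direct look at configuration at these two ring carbons, and in this pair the read-out does not separate the two arrangements. Whatever gap exists could come only from the spatial arrangement, because nothing else separates the two structures: the fact that compounds 2 and 3 differ only in the configuration as drawn

This single pair cannot show whether configuration at these ring carbons would matter as little with a longer chain, or with a carboxylic acid in place of the dimethyl amide. The compounds shown also leave open whether the two mirror images would stay this close in any read-out other than this cell-based one.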